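The source may hold more compounds than are shown below. What is called first, only, known or untested is meant among the compounds shown, and "the series" means these compounds.

Measured compounds:

Compound 1 `CCN(Cc1ccccc1)c1cccc(C(=O)N2CCc3ccc(OS(N)(=O)=O)cc3C2)c1`: in an assay on HEK293 cells for inhibition of Steryl-sulfatase (Homo sapiens), tested at 0.1 uM (a higher number here means a stronger effect of the compound at the concentration tested, a lower number a weaker effect), compound 1 gives 17.3%.
Compound 2 `NS(=O)(=O)Oc1ccc2c(c1)CN(C(=O)c1cccc(N(Cc3ccccc3)Cc3ccco3)c1)CC2`: in this assay compound 2 gives 27.5%.
Compound 3 `NS(=O)(=O)Oc1ccc2c(c1)CN(C(=O)c1cccc(N3CCCCC3)c1)CC2`: in this assay compound 3 gives 1%.

Compound 3 stands lowest of the three numbers. Its nearest neighbour is compound 1, which lies higher by a step beyond the scatter; compound 2 lies furthest, also beyond the scatter.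

Compound 4 `CCCN(Cc1ccccc1)c1cccc(C(=O)N2CCc3ccc(OS(N)(=O)=O)cc3C2)c1` has not yet been measured. The change from compound 3 is benzyl(propyl)amino in place of piperidin-1-yl on an aromatic carbon. The measured step that bears on it most directly is a number 16.3 percentage points lower from compound 1 to compound 3 (beyond the scatter), which is the same exchange run backwards, except that the chain on the nitrogen is ethyl in compound 1 and propyl in compound 4. The step of a number 10.2 percentage points higher from compound 1 to compound 2 (beyond the scatter) concerns furan-2-yl in place of methyl on the chain carbon and so touches a different part of the group; it offers no direct guide here.

The expectation is therefore a step upward in this assay of roughly the size of the reversed step from compound 1 to compound 3, and compound 4 is estimated at 18%, with a range from 7% to 30%, which means an expected step of a number 17 percentage points higher from compound 3 to compound 4 (beyond the scatter).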

Compound 4, a percentage reported as inhibition, at one concentration (the size of the read-out at that concentration, not a potency): 23.1%
The estimate for compound 4 lay 5.1 percentage points below the measured number; the measured number falls inside the stated range.
By their numbers in this assay, from the lowest: compound 3; then compounds 1, 4 and 2 (each within the scatter of the next, the first and the last beyond it).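

In this assay, benzyl(propyl)amino in place of piperidin-1-yl on the aromatic carbon gives a number 22.1 percentage points higher from compound 3 to compound 4 (beyond the scatter), so a second open benzyl-bearing amine, with propyl rather than ethyl on the nitrogen, also stands clear of the piperidine compound. Lengthening the chain by one carbon gives a number 5.8 percentage points higher from compound 1 to compound 4 (within the scatter), and exchanging the furan-2-yl end of the substituent for ethyl gives a number 4.4 percentage points lower from compound 2 to compound 4 (within the scatter); neither step separates the compounds, even though the earlier exchange of methyl for furan-2-yl gave a number 10.2 percentage points higher from compound 1 to compound 2 (beyond the scatter), so the furan-2-yl group cannot be ranked above the propyl chain in this series. Nothing available explains these steps.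

The compounds shown leave open whether the benzyl group or the open, unringed amine accounts for the difference from piperidin-1-yl, a question that a diethylamino or a 4-phenylpiperidin-1-yl group at this aromatic carbon would help to separate. As far as these compounds go, it also remains open whether a longer chain such as butyl or pentyl on the nitrogen would move the read-out beyond the scatter of compound 4.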